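A few compounds are considered here, and "the series" means these few. Any claim that something is new, unique, unknown or untested is made for them only; others in the source may bear on it.

Measured compounds:
compound 1 `Cc1cc(C)cc(S(=O)(=O)c2c(C(=O)N[C@@H]3CCN(Cc4cccnc4)C3)[nH]c3ccc(Cl)cc23)c1` — 36500 nM
compound 2 `Cc1cc(C)cc(S(=O)(=O)c2c(C(=O)NC3CN(Cc4ccccc4C#N)C3)[nH]c3ccc(Cl)cc23)c1` — > 234000 nM

In an ADME assay on MT4 cells (Homo sapiens) for cytotoxicity, read by MTT assay, with a stated time of 5 days (on this read-out lower numbers stand for higher toxicity in this test and higher numbers for lower toxicity in this test), compound 1 gives 36500 nM. Among the compounds with values here, of the two compounds it is the only one that returns a number. Within the data shown here, compound 2 reaches only a limit of this test, > 234000 nM, which is not a number and gives no step against compound 1; what the pair shows is the limit of > 234000 nM in this assay, at which 1 of the 2 values shown sits, and the two values agree only in that neither points to marked toxicity. Among the measured compounds shown here, no step between measured compounds that differ in one place is available, so no measured change can be carried over to compound 3 `CCCS(=O)(=O)NC(=O)c1[nH]c2ccc(Cl)cc2c1S(=O)(=O)c1cc(C)cc(C)c1`.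

Compound 3 is drawn from compound 1 by a single exchange, (propylsulfonyl in place of 1-((pyridin-3-yl)methyl)pyrrolidin-3-yl on an amide-type nitrogen). Since nothing measured on the two compounds speaks for a large effect of such an exchange, the expected step is small, within the scatter or at most a modest move toward lower toxicity; the expected step in this assay is a 1.6-fold higher number from compound 1 to compound 3 (0.22 log units; within the scatter). For compound 3 the estimated value in this assay is 60000 nM, with a range from 15000 nM to 240000 nM, and a fair chance that the test returns only a limit.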

Compound 3, half-maximal cytotoxic concentration: 146000 nM
Estimate against measurement, compound 3: 2.4-fold (0.39 log units) below; the measured number falls inside the stated range.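

In this assay, within the data shown here, propylsulfonyl in place of 1-((pyridin-3-yl)methyl)pyrrolidin-3-yl on an amide-type nitrogen gives a 4.0-fold higher number from compound 1 to compound 3 (0.60 log units; beyond the scatter), the first step that can be read as a number. The step is modest but beyond the scatter, so this position does affect the read-out, and this change moves it toward lower toxicity in this test. The entering group has no ring, yet compound 3 still returns a number rather than a limit, so the loss of both rings of the leaving group does not take this compound out of the measurable range.

Among these compounds, compound 2 stays at a limit of this test, which is not a number and gives no step: the limit of > 234000 nM in this assay, at which 1 of the 3 values shown sits. Whether the step of compound 3 belongs to the sulfonyl group, to the propyl chain or to the loss of the five-membered non-aromatic ring and the six-membered aromatic ring remains open, and an acetyl group or a longer chain such as butylsulfonyl on the same nitrogen would help to separate these parts.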